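The source may hold more compounds than are shown below. What is called first, only, known or untested is meant among the compounds shown, and "the series" means these compounds.

Measured compounds:
compound 1, `NC(=O)c1c(NC(=O)c2ccccc2Cl)sc2c1CCN(Cc1c(Cl)cccc1Cl)C2`, 4740 nM
compound 2, `NC(=O)c1c(NC(=O)c2ccccc2Cl)sc2c1CCN(C(=S)Nc1ccccc1-c1ccccc1)C2`, 25800 nM

Both were run in a functional assay on MKN-74 cells (Homo sapiens) for antiproliferative activity, with a stated time of 24 h; on this read-out higher numbers stand for weaker inhibition and lower numbers for stronger inhibition. Compound 2 has the higher of the two numbers; compound 1 stands lower, and that gap lies beyond the scatter. Compound 3, `NC(=O)c1c(NC(=O)c2ccccc2Cl)sc2c1CCN(C(=S)Nc1c(Cl)cccc1Cl)C2`, remains unmeasured. It differs from compound 2 by 2,6-dichlorophenyl in place of 2-phenylphenyl on an amide-type nitrogen. Among the measured compounds shown here, no measured pair of this kind exists, so the size of the step is open; a moderate move toward a lower number is expected for compound 3, which is estimated at 12000 nM, with a range of 3000 nM to 40000 nM. The step this estimate means, a 2.2-fold lower number from compound 2 to compound 3 (0.33 log units; beyond the scatter), is an expectation only.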

Compound 3, half-maximal inhibitory concentration: 4020 nM
Beside the measured number, compound 3's estimate is 3.0-fold (0.47 log units) above it; the measured number falls inside the stated range.
By their numbers in this assay, from the lowest: compounds 3 and 1 (each within the scatter of the next); then compound 2.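

In this assay, 2,6-dichlorophenyl in place of 2-phenylphenyl on the amide-type nitrogen gives a 6.4-fold lower number from compound 2 to compound 3 (0.81 log units; beyond the scatter), so the number responds to the group at this position. The exchange of the whole group on the ring amine nitrogen, a 1.2-fold lower number from compound 1 to compound 3 (0.07 log units; within the scatter), does not separate compound 3 from compound 1. No data on hand give a reason for either step.

Among the compounds shown here, the single exchange removes one aromatic ring and adds two chlorines together, so their shares remain unresolved. Plain phenyl or 2-chlorophenyl at this position would separate them.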